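Notes on a chromene series: triazole nitrogen substituent change

A few compounds are considered here, and "the series" means these few. Any claim that something is new, unique, unknown or untested is made for them only; others in the source may bear on it.

Measured so far in a functional assay on DU-145 cells (Homo sapiens) for inhibition, read by MTT assay, with a stated time of 24 h; on this read-out higher numbers stand for weaker inhibition and lower numbers for stronger inhibition:
compound 1 `CCOC(=O)C1=Cc2ccccc2OC1(OCc1cc(-c2ccc(C)cc2)no1)C(F)(F)F`, > 150000 nM (a limit of the assay)
compound 2 `CCOC(=O)C1=Cc2ccccc2OC1(OCc1cn(CC(=O)NC2CCCCC2)nn1)C(F)(F)F`, 10200 nM
compound 3 `CCOC(=O)C1=Cc2ccccc2OC1(OCc1cn(CC(=O)Nc2ccc(C)cc2)nn1)C(F)(F)F`, > 150000 nM (a limit of the assay)

Compound 3 stands only at a limit in this assay, and its value is therefore not a number. It shares that limit with compound 1, as the limit of > 150000 nM in this assay, at which 2 of the 3 values shown sit, records. Within the data shown here, compound 2 is the one member of the series with a measured number, and the single step that links it to compound 3, an at least 14-fold higher number from compound 2 to compound 3 (1.16 log units; beyond the scatter), shows how sharply the series falls off when a 4-methylphenyl replaces a cyclohexyl on the amide-type nitrogen.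

Compound 4 `CCOC(=O)C1=Cc2ccccc2OC1(OCc1cn(-c2ccccc2)nn1)C(F)(F)F` is the next member. It differs from compound 3 in one place: phenyl in place of ((4-methylphenyl)carbamoyl)methyl on an aromatic nitrogen. Among the measured compounds shown here, no measured step covers this change, since both the amide link and the methyl group are removed together and a phenyl is set straight on the five-membered aromatic ring with 3 nitrogen. For the measured compounds named here, the only bearing is indirect: compound 3 sits at a limit, and the one numbered value, compound 2, lies well inside the range. Compound 4 is expected to land between those two positions, the step of an at least 3.0-fold lower number from compound 3 to compound 4 (0.47 log units; beyond the scatter) being a guess at improvement from an undefined starting point. The estimate for compound 4 in this assay is 50000 nM, with a range from 8000 nM to 150000 nM.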

Compound 4, half-maximal inhibitory concentration: > 150000 nM
Compound 4 gave a limit, no number; the forecaster's own chance of this, stated with the estimate: 45%; middle value at least 3.0-fold (0.47 log units) from the limit.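

Notes on the position: with phenyl on the aromatic nitrogen, the amide-type nitrogen, the amide hydrogen and the carbonyl are all gone, yet this assay still gives compound 4 only a limit, not a number, so the 4-methylphenyl amide of compound 3 is not the only group at this position that ends there: the limit of > 150000 nM in this assay, at which 3 of the 4 values shown sit.

Phenyl in place of (cyclohexylcarbamoyl)methyl gives an at least 14-fold higher number from compound 2 to compound 4 (1.16 log units; beyond the scatter), and compound 2 remains the only compound on this five-membered ring with a measured number. The step between compound 3 and compound 4 cannot be read, since both values are limits.

On these data alone, it remains open which part of the (cyclohexylcarbamoyl)methyl group the measured number of compound 2 depends on. Also open, as far as these compounds go, is how a longer chain ending in an amine or a carboxylic acid at this nitrogen would read in this assay.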